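Methylthiophene analogue of compound 1: microsomal half-life outlook

The source may report more compounds than this note shows. Statements on the series, on what has been measured and on what is new or still open speak of the compounds shown alone.

Working notes on the series. Compound 1 `NC(=O)COc1ccc2c(c1)S(=O)(=O)N=C(c1c(O)c(-c3cccs3)nn(CCC3CC3)c1=O)N2` gives 0.2 h in an in vitro ADME assay on microsomes from liver (Homo sapiens) for metabolic stability (on this read-out lower numbers stand for a shorter-lived compound and higher numbers for a longer-lived compound), the lower of the two numbers obtained so far. Compound 2 `NC(=O)COc1ccc2c(c1)S(=O)(=O)N=C(c1c(O)c(-c3cccs3)nn(CC3CCC3)c1=O)N2` gives 0.367 h in this assay, and the step of a 1.8-fold higher number from compound 1 to compound 2 (0.26 log units; within the scatter) concerns only the chain on the ring nitrogen. Compound 3 `Cc1ccc(-c2nn(CCC3CC3)c(=O)c(C3=NS(=O)(=O)c4cc(OCC(N)=O)ccc4N3)c2O)s1` differs from compound 1 by methyl in place of hydrogen on an aromatic carbon. Among the compounds with values here, no measured step touches this ring position, so the single chain step gives no guidance here, and for compound 3 no shift beyond the scatter is expected in this assay. The expected step is a 1.3-fold higher number from compound 1 to compound 3 (0.10 log units; within the scatter). Compound 3 is estimated at 0.25 h, within 0.12 h to 0.5 h.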

Compound 3, half-life: 0.7 h
Compound 3: the middle estimate sits 2.8-fold (0.45 log units) below what was measured; measured number above the stated range.
By their numbers in this assay, from the lowest: compounds 1, 2 and 3 (each within the scatter of the next, the first and the last beyond it).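

At this place on the ring, next to the ring sulfur, thiophen-2-yl to 5-methylthiophen-2-yl gives a 3.5-fold higher number from compound 1 to compound 3 (0.54 log units; beyond the scatter) in this assay. Within the data shown here, a single methyl here therefore moves the half-life beyond the scatter, whereas the only earlier step, a 1.8-fold higher number from compound 1 to compound 2 (0.26 log units; within the scatter), stays within it. No measurement in hand bears on why this small change has this effect.

Going by these compounds, whether the methyl gives the same gain on the cyclobutyl chain of compound 2 remains open. Also open, on these data alone, is whether ethyl, chlorine or methoxy at this place would match it.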